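Amino in place of chloro: notes on compound 3

The source may hold more compounds than are shown below. What is called first, only, known or untested is meant among the compounds shown, and "the series" means these compounds.

Compound 1 (`Cc1ccc2oc(-c3ccc(Cl)cc3)cc(=O)c2c1`) offers no baseline: in a functional assay on HepG2 cells (Homo sapiens) for cytotoxicity, read by MTT assay, with a stated time of 48 h (a lower number here means a stronger inhibitor, a higher number a weaker inhibitor), compound 1 stands at "not determined" (no result reported) and has no single number. Compound 2 (`Cc1ccc2oc(-c3ccccc3Cl)cc(=O)c2c1`) is an isomer of compound 1 with the chloro group placed differently. In this assay compound 2 reads 6230 nM and this is the only figure available for the series.

The unmeasured compound 3 (`Cc1ccc2oc(-c3ccc(N)cc3)cc(=O)c2c1`) arises through a single exchange. The change is amino in place of chloro on an aromatic carbon (amino in place of chloro on an aromatic carbon, para to a large group).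

Among the measured compounds shown here, no measured pair shows this exchange, so the data give neither the size nor the direction of its effect. The working expectation in this assay is no step beyond the scatter, with no direction favoured, and the uncertainty stays wide. With compound 2 at 6230 nM as the sole reference, the expected value stays in that region. In this assay the estimated value for compound 3 is 6000 nM with an expected range from 1500 nM to 25000 nM as the outer bounds.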

Compound 3, half-maximal inhibitory concentration: 21300 nM
Compound 3: middle estimate off by 3.6-fold (0.55 log units), on the low side, and the stated range covers the measured number.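

In this assay compound 1 stands at "not determined" (no result reported), and compound 3 therefore yields no readable step from compound 1. The compounds shown leave open the size and direction of the effect of amino in place of chloro in this assay. No available evidence bears on the result for compound 3.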